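Vinyl Ether in Place of Methyl Ether on the Shared Core

The source may hold more compounds than are shown below. What is called first, only, known or untested is meant among the compounds shown, and "the series" means these compounds.

Compound 1 `COc1cc(N2CCCNCC2)cnc1Cl` gives 91.2 nM in a functional assay on HEK293 cells for agonist activity at Neuronal acetylcholine receptor; alpha4/beta2 (Homo sapiens), read by FLIPR and calcium flux; on this read-out lower numbers stand for an effect already at smaller amounts and higher numbers for an effect only at larger amounts of compound. Compound 2 `C=COc1cc(N2CCCNCC2)cnc1Br` gives 110 nM in this assay. Compound 3 `COc1cncc(N2CCCNCC2)c1` gives 1410 nM in this assay.

Compound 3 shows the highest number of the three, and the step of a 15-fold higher number from compound 1 to compound 3 (1.19 log units; beyond the scatter) lies beyond the scatter. Compound 4 `C=COc1cncc(N2CCCNCC2)c1` differs from compound 3 by vinyl in place of methyl on an oxygen on an aromatic ring. Within the data shown here, no measured pair changes only this ether group. Compound 1 and compound 2 differ in two places, one of them this same ether group, and their two values lie within the scatter of each other, which gives only weak support for a small effect. For compound 4 the expected step in this assay is a 1.0-fold lower number from compound 3 to compound 4 (0.00 log units; within the scatter), none beyond the scatter. Compound 4 is therefore estimated at 1400 nM, with a range from 500 nM to 4000 nM.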

Compound 4, half-maximal effective concentration: 1100 nM
Compound 4: the middle estimate sits 1.3-fold (0.10 log units) above what was measured; measured number inside the range.
By their numbers in this assay, from the lowest: compounds 1 and 2 (each within the scatter of the next); then compounds 4 and 3 (each within the scatter of the next).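

In this assay the change from methoxy to vinyloxy, taken alone, gives a 1.3-fold lower number from compound 3 to compound 4 (0.11 log units; within the scatter) and so cannot be told apart from the scatter. Hydrogen in place of bromo on an aromatic carbon gives a 10-fold higher number from compound 2 to compound 4 (1.00 log units; beyond the scatter) and this is beyond the scatter, in the same direction as the step from chloro to hydrogen among the methyl ethers. No measurement shown explains either result.

Still open, on these data alone, is how a longer chain on this oxygen, such as propyl, would compare with methyl and vinyl. Also open, as far as these compounds go, is whether fluoro on that aromatic carbon would act like chloro and bromo.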